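Methyl on the furan ring of compound 3

The compounds below may be only part of what the source reports. "The series", "measured", "known", "first", "only" and "open" are said of these compounds alone.

The three measured compounds share one core and differ only in the group on the saturated ring carbon. Compound 1 `N#CC1=C(N)N(c2ccc(S(N)(=O)=O)cc2)C2=C(C(=O)CCC2)C1c1ccccc1` carries a phenyl there; in a functional assay on Ehrlich cells (Mus musculus) for antiproliferative activity, read by trypan blue exclusion, with a stated time of 2 h, tested at 25 ug/mL (a higher number here means a stronger effect of the compound at the concentration tested, a lower number a weaker effect), compound 1 gives 30%. Compound 2 `Cc1ccc(C2C(C#N)=C(N)N(c3ccc(S(N)(=O)=O)cc3)C3=C2C(=O)CCC3)cc1` carries a 4-methylphenyl; in this assay compound 2 gives 30%. The change between them is methyl in place of hydrogen on an aromatic carbon and gives no change at the digits printed from compound 1 to compound 2 (within the scatter). Compound 3 `N#CC1=C(N)N(c2ccc(S(N)(=O)=O)cc2)C2=C(C(=O)CCC2)C1c1ccco1` carries a furan-2-yl; in this assay compound 3 gives 0%, the lowest of the three. The cores of compound 1 and compound 3 differ by furan-2-yl in place of phenyl on a saturated ring carbon, which gives a number 30 percentage points lower from compound 1 to compound 3 (beyond the scatter).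

Compound 4 `Cc1ccoc1C1C(C#N)=C(N)N(c2ccc(S(N)(=O)=O)cc2)C2=C1C(=O)CCC2` is not yet measured. It differs from compound 3 by methyl in place of hydrogen on an aromatic carbon, the same kind of change as from compound 1 to compound 2, though the place is not the same: there on a six-membered aromatic ring of carbon only, para to a large group; here on a five-membered aromatic ring with 1 oxygen, next to the ring atom that bears a large group, two ring bonds from the ring oxygen. Because the earlier methyl gave no change at the digits printed from compound 1 to compound 2 (within the scatter), a step of only a number 5 percentage points higher from compound 3 to compound 4 (within the scatter) is expected. Compound 4 is estimated at 5%, between 0% and 20%.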

Compound 4, a percentage reported as activity, at one concentration (the size of the read-out at that concentration, not a potency): 10%
Beside the measured number, compound 4's estimate is 5 percentage points below it; measured number inside the range.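

In this assay the methyl change carries from one core to the other without a detectable difference between the two steps: the same change on two cores in this assay, no change at the digits printed (within the scatter) from compound 1 to compound 2 and a number 10 percentage points higher (within the scatter) from compound 3 to compound 4, 10 percentage points apart, within the scatter of two such steps

For the compounds shown here, this rests on only two pairs, with the methyl at a different place in each, so it does not show that the step is independent of the ring or of the place on it, nor does it give the methyl a real effect on either core. Nor does the methyl remove the effect of exchanging the ring, since 3-methylfuran-2-yl still leaves a number 20 percentage points lower from compound 2 to compound 4 (beyond the scatter) and a number 20 percentage points lower from compound 1 to compound 4 (beyond the scatter), alongside the methyl step itself of a number 10 percentage points higher from compound 3 to compound 4 (within the scatter).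

The compounds shown leave open whether an amine, a carboxylic acid or a longer chain in place of this methyl would follow the same course on the two cores. They also leave open whether a methyl elsewhere on the furan ring would read the same at this single concentration.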